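The source may report more compounds than this note shows. Statements on the series, on what has been measured and on what is new or still open speak of the compounds shown alone.

Compound 1, `CCCNc1nc(N)nc2c1ncn2/C=C1/CC1(CO)CO`: in an ADME assay on CCRF-HSB-2 cells (Homo sapiens) for cytotoxicity, with a stated time of 7 days (a lower number here means that less compound is tolerated, a higher number that more compound is tolerated), compound 1 gives > 20000 nM, which is a limit of the assay.
Compound 2, `Nc1nc(N2CCCC2)c2ncn(/C=C3/CC3(CO)CO)c2n1`: in this assay compound 2 gives > 20000 nM, again a limit.
Compound 3, `CN(C)c1nc(N)nc2c1ncn2/C=C1/CC1(CO)CO`: in this assay compound 3 gives > 20000 nM, also a limit.

Compound 3 therefore stands only at a limit, and the two other values shown sit at the same limit; this is recorded as the limit of > 20000 nM in this assay, at which 3 of the 3 values shown sit. The steps among the measured compounds, a step that the two limits leave unreadable from compound 1 to compound 2, a step that the two limits leave unreadable from compound 1 to compound 3 and a step that the two limits leave unreadable from compound 2 to compound 3, are all unreadable in size, since each joins two limits.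

Compound 4, `CCCCCCOc1nc(N)nc2c1ncn2/C=C1/CC1(CO)CO`, is not yet measured in this assay. It differs from compound 3 by hexyloxy in place of dimethylamino on an aromatic carbon. Within the data shown here, none of the measured steps can show how far such a change moves the read-out, since every one of them joins two limits; they show only that changing the group at this position among propylamino, pyrrolidin-1-yl and dimethylamino left all three compounds at the limit.

Compound 4 is therefore expected to stay at the limit as well, an expected step that the limit leaves unreadable from compound 3 to compound 4. The estimate for compound 4 is 30000 nM, with a range from 10000 nM to 100000 nM.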

Compound 4, half-maximal cytotoxic concentration: > 20000 nM
Compound 4 was reported as a limit (the forecaster's own chance of this, stated with the estimate: 85%); the middle value does not contradict the limit.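

Compound 4 stays at the same limit as compound 1, compound 2 and compound 3 in this assay, and no step from any of these to compound 4 can be read: the limit of > 20000 nM in this assay, at which 4 of the 4 values shown sit.

The compounds shown leave open how far any of these groups moves the cytotoxic concentration, and whether any of them brings it to a measurable value.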